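A few compounds are considered here, and "the series" means these few. Any claim that something is new, unique, unknown or untested is made for them only; others in the source may bear on it.

Compound 1 `OCc1nnc(-c2ccc(N3CCC(Oc4ccccc4C(F)(F)F)CC3)nn2)s1` gives 3.2 nM in an assay on microsomes from liver for inhibition of acyl-CoA desaturase 1 (Rattus norvegicus); a higher number here means a weaker inhibitor, a lower number a stronger inhibitor. Within the data shown here, compound 2 `FC(F)(F)c1ccccc1OC1CCN(c2ccc(-c3nnco3)nn2)CC1` gives 22 nM in this assay, and the only step between measured compounds that differ in one place is a 6.9-fold higher number from compound 1 to compound 2 (0.84 log units; beyond the scatter), a change at the far end of the shared core from the phenyl ether. Compound 3 `CC(=O)c1ccccc1OC1CCN(c2ccc(-n3ccnc3)nn2)CC1` gives 34 nM in this assay; of the three numbers it is the highest, with compound 2 nearest and within the scatter of it, and compound 1 furthest, well below it.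

Compound 4 `CCc1ccccc1OC1CCN(c2ccc(-n3ccnc3)nn2)CC1` differs from compound 3 in one place: ethyl in place of acetyl on an aromatic carbon. Among the measured compounds shown here, compounds 1 and 2 both carry trifluoromethyl at that same place, so none of the measured compounds shows what acetyl against ethyl does there, and the one measured step, which alters the other end of the core, does not bear on this change. For the measured compounds named here, with no relevant step to lean on, the expectation is that the number stays close to that of compound 3, with a slight drift toward a weaker inhibitor as the more likely direction. The estimated step is a 1.8-fold higher number from compound 3 to compound 4 (0.25 log units; within the scatter). Compound 4 is therefore expected to give about 60 nM in this assay, with a likely range from 20 nM to 200 nM.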

Compound 4, half-maximal inhibitory concentration: 4 nM
The estimate for compound 4 lay 15-fold (1.18 log units) above the measured number, and the stated range ends above it.
By their numbers in this assay, from the lowest: compounds 1 and 4 (each within the scatter of the next); then compounds 2 and 3 (each within the scatter of the next).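

Ethyl in place of acetyl on this aromatic carbon gives an 8.5-fold lower number from compound 3 to compound 4 (0.93 log units; beyond the scatter) in this assay, the first sign that the group held here matters in this series, since compounds 1 and 2 both carry trifluoromethyl at this place and could not show it. The step also shows that the carbonyl of acetyl is not needed for a low number: going from 2-acetylphenyl to 2-ethylphenyl removes one heavy atom and the only hydrogen-bond acceptor of the group, and the inhibitor becomes stronger, not weaker. Nothing measured here says why the number falls so far.

The compounds shown leave open how a methoxy group, an amine or a longer chain such as propyl would fare on this same aromatic carbon. This exchange is also seen with only one partner, the group that compound 3 and compound 4 share in place of the 1,3,4-oxadiazol-2-yl of compound 2, so a step of the same size cannot be assumed with that oxadiazolyl group or with the 5-(hydroxymethyl)-1,3,4-thiadiazol-2-yl of compound 1.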